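A few compounds are considered here, and "the series" means these few. Any claim that something is new, unique, unknown or untested is made for them only; others in the source may bear on it.

In an ADME assay on HepG2 cells (Homo sapiens) for inhibition, read by resazurin assay, with a stated time of 48 h (a lower number here means that less compound is needed, a higher number that more compound is needed for the effect), compound 1 `O=C(Nc1ccc2sc(-c3cccc(F)c3)nc2c1)N1CCCCC1` gives > 50000 nM, which is a limit of the assay and not a number. Compound 2 `O=C(Nc1ccc2sc(-c3ccc(F)c(F)c3)nc2c1)N1CCCC1` gives > 50000 nM, which is likewise a limit. The record so far is therefore (the limit of > 50000 nM in this assay, at which 2 of the 2 values shown sit), and compound 2 has only this limit to mark its standing, with no exact number.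

Compound 3 `O=C(Nc1ccc2sc(-c3ccc(F)c(F)c3)nc2c1)N1CCCCC1` differs from compound 2 in one place: piperidin-1-yl in place of pyrrolidin-1-yl on a carbonyl carbon. In words, piperidin-1-yl stands in place of pyrrolidin-1-yl on a carbonyl carbon. For the measured compounds named here, no pair of measured compounds isolates this change, so its size in this assay has not been observed directly. Compound 1 already carries piperidin-1-yl on a carbonyl carbon, and its > 50000 nM is also a limit. On that basis, no shift beyond the usual scatter is expected, and the most likely outcome is another reading at the limit of the assay.

The expected step is a number no higher from compound 2 to compound 3 (the limit leaves the size open), an estimate that can only be approximate. For compound 3 the estimated value is 50000 nM, with an expected range from 25000 nM to 100000 nM.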

Compound 3, half-maximal effective concentration: > 50000 nM
Compound 3: no number, only a limit; the forecaster's own chance of this, stated with the estimate: 85%; the middle value lies on the limit itself.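

In this assay compound 3 gives > 50000 nM, which is a limit of the assay and not a number. For the compounds shown here, neither the step to compound 3 from compound 1 nor the one from compound 2 can be read. The compounds shown leave open whether piperidin-1-yl, pyrrolidin-1-yl or the added fluoro changes the reading at all, with every value resting at one limit: the limit of > 50000 nM in this assay, at which 3 of the 3 values shown sit.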